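From methoxy to cyano at an assay limit

The source may report more compounds than this note shows. Statements on the series, on what has been measured and on what is new or still open speak of the compounds shown alone.

In an ADME assay (liver) for metabolic stability, with Liver microsome (Rattus norvegicus) as the target, using microsomes and NADPH, with a stated time of 30 min, at 37 degrees C, tested at 1 uM (a lower number here means slower removal, a higher number faster removal of the compound), compound 1 (`Nc1ccc(S(=O)(=O)c2ccc(-c3ccc(C(O)(C(F)(F)F)C(F)(F)F)cn3)cc2)cn1`) gives < 14 mL.min-1.g-1 as a limit of the assay, not a number. On these data alone, compound 2 (`COc1cc(C(O)(C(F)(F)F)C(F)(F)F)cnc1-c1ccc(S(=O)(=O)c2ccc(N)nc2)cc1`) gives < 14 mL.min-1.g-1 as a limit too, so its exact place is unknown. What the data show so far is the limit of < 14 mL.min-1.g-1 in this assay, at which 2 of the 2 values shown sit, and nothing more precise.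

Compound 3 (`N#Cc1cc(C(O)(C(F)(F)F)C(F)(F)F)cnc1-c1ccc(S(=O)(=O)c2ccc(N)nc2)cc1`) has cyano in place of methoxy on an aromatic carbon, ortho to a large group and two atoms from the ring nitrogen: cyano in place of methoxy on an aromatic carbon is the full change.

For the measured compounds named here, the one measured step that bears on this is a step that the two limits leave unreadable from compound 1 to compound 2 at that same aromatic carbon. Its size cannot be read, and it offers no direction. With hydrogen and methoxy both reported only as limits, no step beyond the usual scatter is expected in this assay for the cyano change. The expected step is a step that the limit leaves unreadable from compound 2 to compound 3 on this estimate, with no direction favoured. Compound 3 is estimated at 10 mL.min-1.g-1 with an expected range from 5 mL.min-1.g-1 to 20 mL.min-1.g-1. A limit of the assay rather than a number may well be the outcome for compound 3.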

Compound 3, intrinsic clearance in microsomes: 27 mL.min-1.g-1
Compound 3: the middle estimate sits 2.7-fold (0.43 log units) below what was measured, outside the stated range (above it).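

Of the three compounds, only compound 3 gives a number rather than a limit in this assay: the limit of < 14 mL.min-1.g-1 in this assay, at which 2 of the 3 values shown sit. Cyano in place of methoxy gives an at least 1.9-fold higher number from compound 2 to compound 3 (0.28 log units; that floor lies within the scatter), and cyano in place of hydrogen at the same aromatic carbon gives an at least 1.9-fold higher number from compound 1 to compound 3 (0.28 log units; that floor lies within the scatter); both are floors rather than measured sizes, so neither step is shown to go beyond the scatter. What this adds is that the group on this carbon can separate compounds in this read-out, since the cyano compound gives a number where the hydrogen and methoxy compounds give only the limit, although the step between those two cannot be read.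

On these data alone, how far compounds 1 and 2 lie under their shared limit remains unknown, and with it the true size of both steps. The compounds shown also do not tell whether a primary amide or a chlorine atom on this aromatic carbon would stay at the limit or give a number, as the cyano group does in compound 3.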